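Isobutyl to isopropyl in a series at its limit

A few compounds are considered here, and "the series" means these few. Any claim that something is new, unique, unknown or untested is made for them only; others in the source may bear on it.

Values in a functional assay on cells (Homo sapiens) for cytotoxicity, read by MTT assay, with a stated time of 72 h (on this read-out lower numbers stand for stronger inhibition and higher numbers for weaker inhibition), follow.
- Compound 1 `CC(C)(C)c1nc2ccccc2n1C(=O)c1cccc2ccccc12` gives > 10000 nM as a limit.
- Compound 2 `O=C(c1cccc2ccccc12)n1c(C2CCC2)nc2ccccc21` gives > 10000 nM as a limit.
- Compound 3 `COc1ccc(C(=O)n2c(CC(C)C)nc3ccccc32)cc1` gives > 10000 nM as a limit.

Compound 3 therefore has no number, only the limit > 10000 nM and nothing finer. Going by the values given here, the series so far rests on the limit of > 10000 nM in this assay, at which 3 of the 3 values shown sit, and holds no measured value inside the range of the assay. Compound 4 `COc1ccc(C(=O)n2c(C(C)C)nc3ccccc32)cc1` carries one change, isopropyl in place of isobutyl on an aromatic carbon and in words isopropyl in place of isobutyl on an aromatic carbon, between two ring nitrogen atoms. Among the compounds with values here, the one measured step that the two limits leave unreadable from compound 1 to compound 2 also concerns a group at this carbon, but it cannot be sized and gives no direction. Within the data shown here, no measured step thus points to a gain in this assay for this small change. The expected outcome a number no higher from compound 3 to compound 4 (the limit leaves the size open) is no step beyond the scatter, in either direction. For compound 4 the estimate is 10000 nM with an expected range from 3000 nM to 30000 nM and a report as a limit again being the likeliest result.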

Compound 4, half-maximal inhibitory concentration: > 10000 nM
Compound 4 was reported as a limit; the forecaster's own chance of this, stated with the estimate: 75%; the middle value lies on the limit itself.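

In this assay compound 4 gives > 10000 nM, a limit and not a number. Compound 3 is also a limit, so no step can be read between compound 3 and compound 4. The compounds shown leave open which change at this carbon, if any, would give a measured value within the range of the assay: the limit of > 10000 nM in this assay, at which 4 of the 4 values shown sit.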